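This account rests on a few compounds, and the source may have more. Where it says the series, first, only, none or still open, it means among the compounds named here.

Among the measured compounds shown here, in a functional assay on HeLa cells (Homo sapiens) for antiproliferative activity, read by CCK-8 assay, with a stated time of 72 h (on this read-out higher numbers stand for weaker inhibition of growth and lower numbers for stronger inhibition of growth), only two compounds carry an entry. Compound 1 `CC[C@@H]1C(=O)N(C)c2cnc(-n3ccc4cc(F)ccc43)nc2N1C1CCCC1` is recorded as "not active" (no number reported) and so gives no number. Compound 2 `CCC1C(=O)N(C)c2cnc(-n3ccc4cc(C(N)=O)ccc43)nc2N1c1ccn(C)n1` gives 27400 nM, the only number shown, while the other entry stands without one. Compound 3 `CCC1C(=O)N(C)c2cnc(-n3ccc4cc(C(=O)NC)ccc43)nc2N1c1ccn(C)n1` differs from compound 2 by methyl in place of hydrogen on an amide-type nitrogen, placed on an amide-type nitrogen whose other neighbour is a carbonyl carbon. For the measured compounds named here, no measured pair shows a change of this kind, so the expected step is none beyond the scatter: a 1.0-fold lower number from compound 2 to compound 3 (0.01 log units; within the scatter). Compound 3 is therefore estimated at 27000 nM, between 10000 nM and 70000 nM.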

Compound 3, concentration for 50% growth inhibition: 6330 nM
Compound 3: middle estimate off by 4.3-fold (0.63 log units), on the high side; the whole stated range lies above it.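

In this assay, methyl in place of hydrogen on the amide-type nitrogen gives a 4.3-fold lower number from compound 2 to compound 3 (0.64 log units; beyond the scatter) and so shows that this nitrogen, whose other neighbour is the carbonyl carbon, is a place where one added methyl moves the number beyond the scatter. Among the compounds shown here, it is the first step available, and it gives the direction for this change in this one pair only. Nothing shown accounts for the step. On these data alone, whether an ethyl or a longer chain on this nitrogen, a second methyl, or a carboxylic acid in place of the amide would continue this direction remains open.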